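Compound 4: hydrogen in place of methyl

A few compounds are considered here, and "the series" means these few. Any claim that something is new, unique, unknown or untested is made for them only; others in the source may bear on it.

In a functional assay on PC-3 cells (Homo sapiens) for cytotoxicity, read by MTT assay, with a stated time of 72 h (on this read-out lower numbers stand for stronger inhibition and higher numbers for weaker inhibition), compound 3 `Cc1ccc2[nH]c3c4cn[nH]c4c4c(c3c2c1)C(=O)NC4=O` gives > 100000 nM, which is a limit and not a number. In this assay compound 2 `COc1ccc2[nH]c3c4cn[nH]c4c4c(c3c2c1)C(=O)NC4=O` gives > 100000 nM, also a limit. Compound 3 therefore stands with compound 2 at the limit of > 100000 nM in this assay, at which 2 of the 3 values shown sit. Compound 1 `Cc1ccc2[nH]c(-n3cccn3)c(C3=C(Br)C(=O)NC3=O)c2c1`, built on a different core, gives a true number in this assay, at 26000 nM. For the measured compounds named here, no measured step connects compound 1 to compound 3.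

The next structural change leads to compound 4 `O=C1NC(=O)c2c1c1[nH]ncc1c1[nH]c3ccccc3c21`: hydrogen in place of methyl on an aromatic carbon. In words, this puts hydrogen in place of methyl on an aromatic carbon, leaving the rest of the core untouched.

Going by the values given here, the only measured step that bears on this change is a step that the two limits leave unreadable from compound 2 to compound 3. It also exchanges a small group on an aromatic carbon, but it has no readable size to carry over. Neither compound on that step leaves the limit, so the evidence gives no direction and no reason to expect a step beyond the scatter in this assay. A further reading at the limit is the most likely outcome. The estimate means a number no higher from compound 3 to compound 4 (the limit leaves the size open), an expected step of no readable size. For compound 4 the estimated value is 100000 nM, with an expected range of 40000 nM to 200000 nM.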

Compound 4, half-maximal inhibitory concentration: > 100000 nM
Compound 4 ended at the assay's limit (the forecaster's own chance of this, stated with the estimate: 85%); the middle value sits exactly at the limit.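

No step among compound 2, compound 3 and compound 4 can be read in this assay, since all three rest on a limit and not on a number: the limit of > 100000 nM in this assay, at which 3 of the 4 values shown sit.

The compounds shown leave open whether methoxy, methyl or hydrogen on that aromatic carbon makes any difference in this assay, and how the shared core relates to the different core of compound 1.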